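A few compounds are considered here, and "the series" means these few. Any claim that something is new, unique, unknown or untested is made for them only; others in the source may bear on it.

Measured so far:
- Compound 1 `COc1ccc(/C=C/C2(C)C=CC(=O)O2)c(OC)c1`: > 1000000 nM
- Compound 2 `CC1(/C=C/c2ccccc2O)C=CC(=O)O1`: > 1000000 nM

Both results come from a functional assay on K562 cells (Homo sapiens) for inhibition, read by sulforhodamine B assay, with a stated time of 48 h; a higher number here means a weaker inhibitor of growth, a lower number a stronger inhibitor of growth. Compound 2 stands at > 1000000 nM, which is a limit of the assay and not a number. The same is true of compound 1, so the data so far amount to the limit of > 1000000 nM in this assay, at which 2 of the 2 values shown sit.

Compound 3 `COc1ccccc1/C=C/C1(C)C=CC(=O)O1` has not yet been measured. It differs from compound 2 by one change, hydroxy to methoxy: methyl in place of hydrogen on an oxygen on an aromatic ring. Among the measured compounds shown here, no measured pair shows this change alone, so any step in this assay is only an expectation. Compound 1, which also carries methoxy, gives the limit > 1000000 nM, so no step beyond the usual scatter is expected, in either direction. The expected step is a number no higher from compound 2 to compound 3 (the limit leaves the size open). For compound 3 the estimated value is 1000000 nM, with an expected range of 300000 nM to 2000000 nM.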

Compound 3, concentration for total growth inhibition: 860000 nM
Compound 3: the middle estimate sits 1.2-fold (0.07 log units) above what was measured; the measured number falls inside the stated range.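

In this assay, methyl in place of hydrogen on an oxygen on an aromatic ring gives an at least 1.1-fold lower number from compound 2 to compound 3 (0.06 log units; that floor lies within the scatter). Hydrogen in place of methoxy on an aromatic carbon gives an at least 1.1-fold lower number from compound 1 to compound 3 (0.06 log units; that floor lies within the scatter). Compound 3 is the only one of the three with a number rather than a limit, but with both floors within the scatter, neither change can yet be said to alter growth inhibition, and the series still sits mostly at the edge of what can be read: the limit of > 1000000 nM in this assay, at which 2 of the 3 values shown sit.

From the compounds shown here alone, the true size of either step stays open, as does whether any change on this oxygen can bring the number down far enough to matter. An amine or a longer chain on this oxygen lies outside the compounds shown, so what either would do is unknown.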